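The source may report more compounds than this note shows. Statements on the series, on what has been measured and on what is new or still open speak of the compounds shown alone.

Compound 1 `COc1c(OC(C)C)cc2occ(-c3csc4ccccc34)c(=O)c2c1O`: 7200 nM
Compound 2 `COc1cc2occ(-c3csc4ccccc34)c(=O)c2c(OC)c1O`: > 10000 nM
Compound 3 `O=C(/C=C/c1csc2ccccc12)c1ccccc1O`: 5300 nM

These three results come from a functional assay on A549 cells (Homo sapiens) for antiproliferative activity, read by sulforhodamine B assay, with a stated time of 72 h; on this read-out lower numbers stand for stronger inhibition and higher numbers for weaker inhibition. Compound 2 gives > 10000 nM, which is a limit of the assay and not a number. That leaves two true numbers to compare. Compound 3 gives 5300 nM and compound 1 gives 7200 nM, and these two lie within the usual scatter of repeated measurements, so they cannot be told apart.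

The next compound to be tested is compound 4 `COc1ccc(O)c(C(=O)/C=C/c2csc3ccccc23)c1`, and it differs from compound 3 in one place: methoxy in place of hydrogen on an aromatic carbon. The methoxy takes the place of a hydrogen on an aromatic carbon of a six-membered aromatic ring of carbon only, meta to a large group and para to a hydroxy group.

Going by the values given here, no measured pair here shows what such a change does in this assay. Among the compounds with values here, the only guide is compound 3 itself, at 5300 nM, so no shift beyond the scatter is expected, in either direction. The expected 1.2-fold lower number from compound 3 to compound 4 (0.07 log units; within the scatter) is therefore small. For compound 4 the estimated value is 4500 nM, with an expected range from 1500 nM to 10000 nM.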

Compound 4, half-maximal inhibitory concentration: 580 nM
Estimate against measurement, compound 4: 7.8-fold (0.89 log units) above; the measured number lies below the stated range.
By their numbers in this assay, from the lowest: compound 4; then compounds 3 and 1 (each within the scatter of the next). At a limit, above all of these: compound 2.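

In this assay, methoxy in place of hydrogen on an aromatic carbon, para to a hydroxy group and meta to a large group, gives a 9.1-fold lower number from compound 3 to compound 4 (0.96 log units; beyond the scatter), and this lies beyond the scatter. This is the first change in one place among the compounds shown, and it makes clear that this carbon of the six-membered ring is not indifferent: a group of 2 heavy atoms placed there goes with a clear fall in the number, from a starting point that could not be told apart from compound 1. The measurements given here show only the size of this step, and none of them bears on what lies behind it.

The compounds shown leave open whether the lower number belongs to methoxy itself or would also come with another group at this place, such as a chlorine atom, an amine or a longer chain such as ethoxy. They also leave open whether methoxy on another carbon of the same ring would move the number in the same way.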